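Para substituent swap on the anilino ring of compound 3

The source may report more compounds than this note shows. Statements on the series, on what has been measured and on what is new or still open speak of the compounds shown alone.

In a functional assay on MGC-803 cells (Homo sapiens) for cytotoxicity, read by MTT assay, with a stated time of 72 h (a lower number here means a stronger inhibitor, a higher number a weaker inhibitor), compound 1 `CCCCCCCCNc1nc(SCc2ccc(C(F)(F)F)cc2)nc2ccccc12` gives 12600 nM. Compound 2 `FC(F)(F)c1ccc(CSc2nc(Nc3ccccc3C(F)(F)F)c3ccccc3n2)cc1` reaches only the limit of the assay, > 50000 nM, a limit rather than a number (the limit of > 50000 nM in this assay, at which 1 of the 3 values shown sits). Compound 3 `Fc1ccc(Nc2nc(SCc3ccc(C(F)(F)F)cc3)nc3ccccc23)cc1` gives 9620 nM, the lowest of the two numbers shown. The nearest step, a 1.3-fold lower number from compound 1 to compound 3 (0.12 log units; within the scatter), lies within the scatter, so no order is claimed between those two. The step of an at least 5.1-fold lower number from compound 2 to compound 3 (0.71 log units; beyond the scatter) is beyond the scatter.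

Compound 4 `Cc1ccc(Nc2nc(SCc3ccc(C(F)(F)F)cc3)nc3ccccc23)cc1` is not yet measured. It differs from compound 3 by methyl in place of fluoro on an aromatic carbon. Among the measured compounds shown here, no measured step exchanges this group at this position: both measured steps replace the whole group on the ring nitrogen, one within the scatter and one beyond, and neither tells how a small exchange on the same ring will read. The step from compound 3 to compound 4 in this assay is therefore expected to stay within the scatter, a 1.1-fold lower number from compound 3 to compound 4 (0.03 log units; within the scatter). Compound 4 is estimated at 9000 nM in this assay, with a range of 4000 nM to 25000 nM.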

Compound 4, half-maximal inhibitory concentration: 36100 nM
Estimate against measurement, compound 4: 4.0-fold (0.60 log units) below; measured number above the stated range.
By their numbers in this assay, from the lowest: compounds 3 and 1 (each within the scatter of the next); then compound 4. At a limit, above all of these: compound 2.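

In this assay, among the compounds shown here, the aromatic carbon para to a large group responds to a one-atom exchange, which the earlier steps could not show because they replaced the whole group on the nitrogen: a 3.8-fold higher number from compound 3 to compound 4 (0.57 log units; beyond the scatter), with methyl in place of fluoro and no change in the counted donors or acceptors. The 4-methylphenyl group also separates from octyl, a 2.9-fold higher number from compound 1 to compound 4 (0.46 log units; beyond the scatter), whereas the values of compound 3 and compound 1 lie within the scatter of each other, so the two aryl groups on the nitrogen do not read alike. The step of an at least 1.3-fold lower number from compound 2 to compound 4 (0.14 log units; that floor lies within the scatter) gives only a floor, so compound 4 cannot be ordered against compound 2, whose reading is a limit: the limit of > 50000 nM in this assay, at which 1 of the 4 values shown sits.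

As far as these compounds go, it remains open whether the loss of fluoro or the entry of methyl drives the rise. From the compounds shown here alone, how chloro, methoxy, an amine or plain hydrogen would read at this position also remains open.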